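The source may hold more compounds than are shown below. What is called first, only, known or untested is meant among the compounds shown, and "the series" means these compounds.

Measured compounds:
- compound 1 `Cc1c(C(=O)N/N=C\c2ccc(O)cc2)oc2cccc(O)c12`: 21700 nM in a functional assay on PC-3 cells (Homo sapiens) for inhibition; on this read-out higher numbers stand for weaker inhibition and lower numbers for stronger inhibition
- compound 2 `Cc1c(C(=O)N/N=C\c2c(O)cccc2Cl)oc2cccc(O)c12`: 18700 nM in this assay
- compound 3 `Cc1c(C(=O)N/N=C\c2cccc(F)c2)oc2cccc(O)c12`: in this assay compound 3 reaches only the assay limit of >= 40000 nM

Compound 1 holds the highest of the two numbers, its nearest neighbour being compound 2, with a change a 1.2-fold lower number from compound 1 to compound 2 (0.06 log units; within the scatter). Compound 3 sits at a limit (the limit of >= 40000 nM in this assay, at which 1 of the 3 values shown sits), so it gives no number.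

Compound 4 `COc1cccc(/C=N\NC(=O)c2oc3cccc(O)c3c2C)c1` differs from compound 1 as follows: 3-methoxyphenyl in place of 4-hydroxyphenyl on a carbon with a double bond to nitrogen. Among the measured compounds shown here, the step that bears on this change is the one from compound 1 to compound 3, where a 3-fluorophenyl also replaced the 4-hydroxyphenyl and the number moved an at least 1.8-fold higher number from compound 1 to compound 3 (0.26 log units; that floor lies within the scatter); the step of an at least 2.1-fold higher number from compound 2 to compound 3 (0.33 log units; beyond the scatter) points the same way. Both replace the 4-hydroxyphenyl with a ring carrying a single substituent and no hydrogen-bond donor, as compound 4 does. Compound 4 is therefore expected to show a weaker number than compound 1, with a step of a 1.8-fold higher number from compound 1 to compound 4 (0.27 log units; within the scatter), and quite possibly to reach the assay limit. The estimate for compound 4 is 40000 nM, within 18000 nM to 90000 nM.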

Compound 4, half-maximal inhibitory concentration: >= 40000 nM
Compound 4: a limit, no number; the forecaster's own chance of this, stated with the estimate: 50%; the middle value sits exactly at the limit.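

In this assay compound 4 gives >= 40000 nM, which is a limit of the assay and not a number, and it is the second compound shown to stop there, after compound 3: the limit of >= 40000 nM in this assay, at which 2 of the 4 values shown sit.

Replacing the 4-hydroxyphenyl with 3-methoxyphenyl gives an at least 1.8-fold higher number from compound 1 to compound 4 (0.26 log units; that floor lies within the scatter), while the comparison with the 2-chloro-6-hydroxyphenyl gives an at least 2.1-fold higher number from compound 2 to compound 4 (0.33 log units; beyond the scatter). On the carbon with a double bond to nitrogen, the outcome seen with the 3-fluorophenyl ring is therefore not confined to fluoro, and it recurs with a ring that has a hydrogen-bond acceptor but no hydrogen-bond donor.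

The step between compound 3 and compound 4 cannot be read, so methoxy and fluoro stay unranked. On these data alone, whether a 4-aminophenyl or a 4-carboxyphenyl group in this place would give a number below the limit remains open.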